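Swapping the Dichlorobenzyl Group for a Plain Benzyl

The source may report more compounds than this note shows. Statements on the series, on what has been measured and on what is new or still open speak of the compounds shown alone.

Compound 2 `COc1cc2c(=O)c(C(=O)c3ccc(C)cc3)cn(Cc3ccc(Cl)c(Cl)c3)c2cc1OC` is recorded in an ADME assay on Huh-7 cells (Homo sapiens) for cytotoxicity (a higher number here means a weaker inhibitor of growth, a lower number a stronger inhibitor of growth), as "not active" (no number reported), with no number attached. Its companion compound 1 `COc1cc2c(=O)c(C(=O)c3ccc(C)cc3)cn(Cc3ccc(S(N)(=O)=O)cc3)c2cc1OC` carries a sulfonamide instead of the two chlorines. In this assay compound 1 reaches > 25000 nM, which is a limit of the assay rather than a measured number. That both results sit at or past the edge of the assay is the only pattern here, summed up as the limit of > 25000 nM in this assay, at which 1 of the 2 values shown sits. Compound 3 `COc1cc2c(=O)c(C(=O)c3ccc(C)cc3)cn(Cc3ccccc3)c2cc1OC` brings (phenyl in place of 3,4-dichlorophenyl on a saturated chain carbon bound to an aromatic nitrogen). Going by the values given here, no step between the two measured compounds exists, so no change beyond the usual scatter is expected in this assay. Compound 3 is therefore estimated at 30000 nM, within 10000 nM to 100000 nM.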

Compound 3, concentration for 50% growth inhibition: "not active" (no number reported)
Nothing numeric was reported for compound 3, and the estimate cannot be compared.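

Compound 2 and compound 3 both came back without a number, so no step can be read between them. As far as these compounds go, what the 3,4-dichlorobenzyl to benzyl swap does to growth inhibition in this assay stays open.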